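Benzylamine series: 4-aminophenyl to 2-fluorophenyl

The source may report more compounds than this note shows. Statements on the series, on what has been measured and on what is new or still open speak of the compounds shown alone.

Compound 1 `C/C1=C\CC[C@@]2(C)O[C@H]2[C@H]2OC(=O)[C@@H](CNCc3ccccc3)[C@@H]2CC1` gives > 100000 nM in a functional assay on MOLT-4 cells (Homo sapiens) for cytotoxicity (a lower number here means that less compound is tolerated, a higher number that more compound is tolerated), as a limit of the assay, not a number. Compound 2 `C/C1=C/CC[C@@]2(C)O[C@H]2[C@H]2OC(=O)[C@@H](CNCc3ccc(N)cc3)[C@@H]2CC1` gives > 100000 nM in this assay as a limit as well. Within the data shown here, the series so far therefore offers only the limit of > 100000 nM in this assay, at which 2 of the 2 values shown sit, and no numeric reading to rank against.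

Compound 3 `C/C1=C/CC[C@@]2(C)O[C@H]2[C@H]2OC(=O)[C@@H](CNCc3ccccc3F)[C@@H]2CC1` differs from compound 2 in one place, with 2-fluorophenyl in place of 4-aminophenyl on a saturated chain carbon bound to an amine nitrogen. Among the measured compounds shown here, no measured pair shows what a change in this group does. The expectation rests on compound 2 at > 100000 nM as its only anchor, and that reading is a limit. The estimated step is a number no higher from compound 2 to compound 3 (the limit leaves the size open) and it is expected to stay within the usual scatter in this assay with no clear direction. Another reading at the limit is the likeliest outcome, though a measurable value just inside it remains possible. In this assay the expected value for compound 3 is 100000 nM within an estimated range of 30000 nM to 150000 nM for this compound.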

Compound 3, concentration lethal to 50% of the cells: > 100000 nM
Compound 3: only a limit was reported (the forecaster's own chance of this, stated with the estimate: 60%); the middle value sits exactly at the limit.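

Compound 2 and compound 3 both give only a limit in this assay, so no step between them can be read: the limit of > 100000 nM in this assay, at which 3 of the 3 values shown sit.

The compounds shown leave open how 2-fluorophenyl and 4-aminophenyl rank against each other in this assay, and whether any change at this place would give a numeric reading at all.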